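This account rests on a few compounds, and the source may have more. Where it says the series, first, only, none or still open, it means among the compounds named here.

Measured in an ADME assay on MT4 cells (Homo sapiens) for cytotoxicity, read by MTT assay, with a stated time of 4 days; on this read-out higher numbers stand for lower toxicity in this test and lower numbers for higher toxicity in this test:
- compound 1, `CC(=O)Nc1ccc2oc(-c3ccccc3)cc(=O)c2c1`: 184000 nM
- compound 2, `CC(=O)Nc1ccc2oc(-c3ccccc3F)cc(=O)c2c1`: 205000 nM
- compound 3, `CC(=O)Nc1ccc2oc(-c3ccc(F)cc3)cc(=O)c2c1`: 203000 nM

Compound 1 sits at the low end of these three numbers, yet the gaps are small: a 1.1-fold higher number from compound 1 to compound 2 (0.05 log units; within the scatter) and a 1.1-fold higher number from compound 1 to compound 3 (0.04 log units; within the scatter) both lie within the scatter, and so does a 1.0-fold lower number from compound 2 to compound 3 (0.00 log units; within the scatter). Putting a fluoro on the phenyl ring, at either position, has left cytotoxicity in this assay essentially unchanged.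

Compound 4, `CC(=O)Nc1ccc2oc(-c3cccc(C(F)(F)F)c3)cc(=O)c2c1`, is the next step from compound 1: trifluoromethyl in place of hydrogen on an aromatic carbon. Within the data shown here, the only comparable steps are the two fluoro-for-hydrogen changes on the same ring, each within the scatter. Trifluoromethyl is a larger group than fluoro, so nothing measured here covers it directly, but the evidence from compound 2 and compound 3 gives no reason to expect a step beyond the scatter in this assay in either direction. The number expected for compound 4 is therefore close to that of compound 1, at 150000 nM with a range of 70000 nM to 320000 nM, which amounts to an estimated 1.2-fold lower number from compound 1 to compound 4 (0.09 log units; within the scatter).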

Compound 4, half-maximal cytotoxic concentration: 10000 nM
Estimate against measurement, compound 4: 15-fold (1.18 log units) above, and the stated range ends above it.
By their numbers in this assay, from the lowest: compound 4; then compounds 1, 3 and 2 (each within the scatter of the next).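

In this assay, trifluoromethyl in place of hydrogen gives an 18-fold lower number from compound 1 to compound 4 (1.26 log units; beyond the scatter), a step beyond the scatter that points to higher toxicity in this test. The fluoro steps from compound 1 to compound 2 and compound 3 stayed within the scatter, so the phenyl ring of this series can carry a change that moves this read-out strongly, and those fluoro results did not predict what trifluoromethyl would do. Nothing available here explains why this step is so large.

The compounds shown leave open whether the step belongs to the trifluoromethyl group itself or to its place on the ring, meta to a large group, as compound 2 and compound 3 are the 2-fluorophenyl and 4-fluorophenyl compounds. A fluoro, a methyl or a carboxylic acid at that same place would help separate the two.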